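A few compounds are considered here, and "the series" means these few. Any claim that something is new, unique, unknown or untested is made for them only; others in the source may bear on it.

Within the data shown here, in a functional assay on U-373MG ATCC cells (Homo sapiens) for cytotoxicity, read by MTT assay (a higher number here means a weaker inhibitor, a lower number a stronger inhibitor), compound 1 `Oc1ccc(CN(Cc2ccccc2)Cc2ccc(O)c3ncccc23)c2cccnc12` gives 357 nM, the higher of the two numbers so far. Compound 2 `Oc1ccc(CN(Cc2cc(C(F)(F)F)cc(C(F)(F)F)c2)Cc2ccc(O)c3ncccc23)c2cccnc12` gives 96 nM, lower by more than the usual scatter, which makes compound 1 the weaker inhibitor of the pair. Compound 3 `Oc1ccc(CN(Cc2cccs2)Cc2ccc(O)c3ncccc23)c2cccnc12` keeps the core of compound 1 and alters one group: thiophen-2-yl in place of phenyl on a saturated chain carbon bound to an amine nitrogen. Thiophen-2-yl stands in place of phenyl on a saturated chain carbon bound to an amine nitrogen. Among the measured compounds shown here, no measured pair differing in one place is available as a guide, so the expectation rests on the structural change alone. One aromatic ring replaces another, and no step beyond the scatter is expected in this assay, with no firm direction. The estimated change is a 1.1-fold lower number from compound 1 to compound 3 (0.05 log units; within the scatter). For compound 3 the expected value is 320 nM, with an estimated range from 130 nM to 750 nM.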

Compound 3, half-maximal inhibitory concentration: 85 nM
For compound 3 the middle estimate is 3.8-fold (0.58 log units) above the measured one; measured number below the stated range.
By their numbers in this assay, from the lowest: compounds 3 and 2 (each within the scatter of the next); then compound 1.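

In this assay the exchange of phenyl for thiophen-2-yl on a saturated chain carbon bound to an amine nitrogen gives a 4.2-fold lower number from compound 1 to compound 3 (0.62 log units; beyond the scatter) and is the only single-place step shown so far. It shows that this position does not treat one aromatic ring as equal to another, since swapping a six-membered carbon ring for a five-membered ring with one sulfur moves the number beyond the scatter. Nothing available explains this step.

As far as these compounds go, it remains open whether the step depends on the sulfur or on the smaller ring, which furan-2-yl or a pyrrole ring at the same place could help to separate. Also open, from the compounds shown here alone, is whether thiophen-3-yl or a saturated ring such as cyclohexyl would keep the lower number.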